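This account rests on a few compounds, and the source may have more. Where it says the series, first, only, none or still open, it means among the compounds named here.

Compound 1 `CCCCc1oc2ccccc2c1C(=O)c1ccc(OCC(=O)NCc2ccccc2)cc1` and compound 2 `CCCCc1oc2ccccc2c1C(=O)c1ccc(OCC(=O)N[C@H](C)c2ccccc2)cc1` share one core; compound 3 `CCCCc1oc2ccccc2c1C(=O)c1cc(I)c(OCCCN2CCN(C)CC2)c(I)c1` and compound 4 `CCCCc1oc2ccccc2c1C(=O)c1cc(I)c(OCCCN2CCN(CC)CC2)c(I)c1` share another, and the difference between the two cores is not broken down here. In a functional assay on MCF7 cells (Homo sapiens) for antiproliferative activity, read by MTT assay, with a stated time of 24 h (a higher number here means a weaker inhibitor, a lower number a stronger inhibitor), compound 1 gives 19600 nM, compound 2 gives 14100 nM and compound 3 gives 5370 nM, the lowest of the three. The step of a 1.4-fold lower number from compound 1 to compound 2 (0.14 log units; within the scatter) is the change (methyl in place of hydrogen on a saturated chain carbon bound to an amide-type nitrogen and an aromatic carbon). For compound 4 the change is methyl in place of hydrogen on a saturated chain carbon bound to an amine nitrogen in a ring: the same kind of change, but at a different place, a saturated chain carbon bound to an amine nitrogen in a ring rather than one bound to an amide-type nitrogen and an aromatic carbon. Going by the values given here, the step in this assay is expected to be small, a 1.2-fold lower number from compound 3 to compound 4 (0.08 log units; within the scatter), because a 1.4-fold lower number from compound 1 to compound 2 (0.14 log units; within the scatter) is the only earlier step of this kind and lies within the scatter. Compound 4 is therefore estimated at 4500 nM, with a range from 2200 nM to 9500 nM.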

Compound 4, half-maximal inhibitory concentration: 39500 nM
Estimate against measurement, compound 4: 8.8-fold (0.94 log units) below; the measured number lies above the stated range.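

In this assay the change gives a 7.4-fold higher number from compound 3 to compound 4 (0.87 log units; beyond the scatter), so methyl in place of hydrogen does not carry over as a fixed step between these two cores: the same change on two cores in this assay, a 1.4-fold lower number (0.14 log units; within the scatter) from compound 1 to compound 2 and a 7.4-fold higher number (0.87 log units; beyond the scatter) from compound 3 to compound 4, 10-fold (1.01 log units) apart, beyond the scatter of two such steps

The two steps also differ in place, and core and place change together, so the data cannot separate their contributions. Going by these compounds alone, with a single pair on each core, this shows only that the step failed to carry over for these two pairs; it gives neither a rule for other cores nor a cause for the gap.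

Going by these compounds, it remains open whether a 4-propylpiperazin-1-yl group would extend the step seen with 4-ethylpiperazin-1-yl. Also open, on these data alone, is how a 4-methylpiperazin-1-yl to 4-ethylpiperazin-1-yl swap would read on the core of compound 1.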